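From dichlorophenyl to difluorophenyl, starting at a limit

This account rests on a few compounds, and the source may have more. Where it says the series, first, only, none or still open, it means among the compounds named here.

Compound 1 `COc1ccc(-c2cc(/C=C/C(=O)c3ccc(N)cc3)[nH]n2)cc1` gives 34900 nM
Compound 2 `COc1cc(-c2cc(/C=C/C(=O)c3ccc(N)cc3)[nH]n2)cc(OC)c1OC` gives 13400 nM
Compound 3 `COc1cc(-c2cc(/C=C/C(=O)c3ccc(Cl)c(Cl)c3)[nH]n2)cc(OC)c1OC` gives > 100000 nM (a limit, not a number)

In a functional assay on SN12C cells (Homo sapiens) for inhibition, read by sulforhodamine B assay, with a stated time of 48 h (a higher number here means that more compound is tolerated, a lower number that less compound is tolerated), compound 3 gives > 100000 nM as a limit of the assay, not a number. Compound 3 thus stands at the limit of > 100000 nM in this assay, at which 1 of the 3 values shown sits, and has no exact place on the scale.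

Compound 4 `COc1cc(-c2cc(/C=C/C(=O)c3ccc(F)c(F)c3)[nH]n2)cc(OC)c1OC` is still unmeasured and differs from compound 3 in one place, on a carbonyl carbon: 3,4-difluorophenyl in place of 3,4-dichlorophenyl (3,4-difluorophenyl in place of 3,4-dichlorophenyl on a carbonyl carbon).

Among the measured compounds shown here, one measured step touches the same place, 3,4-dichlorophenyl in place of 4-aminophenyl (an at least 7.4-fold higher number from compound 2 to compound 3 (0.87 log units; beyond the scatter)), and it lies beyond the scatter. For the measured compounds named here, no measured step swaps chlorine for fluorine, so the size of that step cannot simply be carried over. Compound 4 also lacks the 4-aminophenyl group, so that step (an at least 7.4-fold higher number from compound 2 to compound 3 (0.87 log units; beyond the scatter)) gives reason to expect it to stay nearer compound 3 than compound 2 at 13400 nM on this scale.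

A small change is expected (an at least 1.5-fold lower number from compound 3 to compound 4 (0.18 log units; that floor lies within the scatter)), and a second limit would be no surprise. Compound 4 is estimated at 65000 nM in this assay with an expected range from 22000 nM to 100000 nM as its likely spread.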

Compound 4, concentration lethal to 50% of the cells: > 100000 nM
Compound 4 was reported as a limit; the forecaster's own chance of this, stated with the estimate: 50%; middle value at least 1.5-fold (0.18 log units) away from the limit.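

In this assay, 3,4-difluorophenyl in place of 4-aminophenyl on the carbonyl carbon gives an at least 7.4-fold higher number from compound 2 to compound 4 (0.87 log units; beyond the scatter), so a second ring without the amine moves in the same direction as the dichlorophenyl ring did, and more compound is again tolerated. Among the compounds that share the core of compound 2, the two that carry the 4-aminophenyl group's replacements now both end at the top of the measurable range, which makes the earlier step look less like a feature of chlorine alone. Because compound 3 and compound 4 stand at the same limit of the assay, which is not a number, the swap of chlorine for fluorine cannot be read, and any difference between them stays hidden: the limit of > 100000 nM in this assay, at which 2 of the 4 values shown sit.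

The compounds shown leave open whether losing the amine is enough for this rise or whether the halogens take part, a question that a plain phenyl ring or a 4-hydroxyphenyl ring on the carbonyl carbon would bear on. Among the compounds shown here, they also leave open whether the same rise appears on the core of compound 1, which has only one methoxy group.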